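The source may report more compounds than this note shows. Statements on the series, on what has been measured and on what is new or still open speak of the compounds shown alone.

Compound 1 `CC1(C)N=C(N)N=C(N)N1c1ccccc1Cl`: in an assay for inhibition of Dihydrofolate reductase (Bos taurus), at pH 6.25 (a higher number here means a more potent compound, by a factor of ten per unit of this negative logarithm, a lower number a less potent compound), compound 1 gives 4.86.
Compound 2 `CC1(C)N=C(N)N=C(N)N1c1ccccc1S`: in this assay compound 2 gives 7.2.
Compound 3 `CC1(C)N=C(N)N=C(N)N1c1ccccc1O`: in this assay compound 3 gives 3.86.

Compound 1 stands second highest of the three values in this assay; compound 3 lies nearest, a number 1.00 log units lower from compound 1 to compound 3 (beyond the scatter), while compound 2 lies furthest, a number 2.34 log units higher from compound 1 to compound 2 (beyond the scatter). For the measured compounds named here, the step to compound 4 `CC1(C)N=C(N)N=C(N)N1c1ccccc1C(F)(F)F` changes only one group on the shared core of compound 1: trifluoromethyl in place of chloro on an aromatic carbon.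

Going by the values given here, none of the measured steps puts a trifluoromethyl group in place of chloro, so no step bears directly on this change. What the measured steps do show is that this one position moves this assay strongly: a number 2.34 log units higher from compound 1 to compound 2 (beyond the scatter), a number 1.00 log units lower from compound 1 to compound 3 (beyond the scatter) and a number 3.34 log units lower from compound 2 to compound 3 (beyond the scatter) are all beyond the scatter. For compound 4 the direction is therefore open, and the expected step is set near zero with a wide range, a number 0.04 log units higher from compound 1 to compound 4 (within the scatter). Compound 4 is estimated at 4.9, within 3.9 to 6.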

Compound 4, logarithm of the reciprocal of the active concentration, log(1/C): 3.15
Estimate against measurement, compound 4: 1.75 log units above; the whole stated range lies above it.
By their numbers in this assay, from the lowest: compound 4; then compound 3; then compound 1; then compound 2.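

In this assay the change from chloro to trifluoromethyl gives a number 1.71 log units lower from compound 1 to compound 4 (beyond the scatter) and places compound 4 at the bottom of the series, with a number 0.71 log units lower from compound 3 to compound 4 (beyond the scatter) and a number 4.05 log units lower from compound 2 to compound 4 (beyond the scatter) as the other two steps. Chloro and trifluoromethyl both count no hydrogen-bond donors, no hydrogen-bond acceptors and no net charge, yet they stand well apart, so these counts alone do not separate the groups at this position. Nothing in the data explains why trifluoromethyl gives so low a number.

A single pair cannot tell whether the larger heavy-atom count of trifluoromethyl goes with the fall, and the compounds shown include no methyl, methoxy, amine or carboxylic acid at this position. They also leave open whether the high number of compound 2 persists with another sulfur group, such as methylthio.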